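The compounds below may be only part of what the source reports. "The series", "measured", "known", "first", "only" and "open" are said of these compounds alone.

Measured compounds:
compound 1, `CCCC(Oc1ccc(-n2cc(C(=O)N(C)C)cn2)cc1)c1ccc(C(=O)NCCC(=O)O)cc1`, 6500 nM
compound 2, `CCC(Oc1ccc(-n2cc(C(F)(F)F)cn2)cc1)c1ccc(C(=O)NCCC(=O)O)cc1`, 1400 nM

Both compounds were tested in an assay on cells for displacement of a labelled ligand from Glucagon receptor (Homo sapiens), in the presence of a further agent that is not named here; a lower number here means a stronger inhibitor, a higher number a weaker inhibitor. Compound 1 gives 6500 nM, the highest of the two numbers shown, so it is the weaker of the pair. Compound 2 gives 1400 nM, a lower number that lies beyond the usual scatter of this assay. For the measured compounds named here, compound 2 differs from compound 1 in more than one place, so no single step between them can be read.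

The compound now in question is compound 3, `CCCC(Oc1ccc(-n2cc(C)cn2)cc1)c1ccc(C(=O)NCCC(=O)O)cc1`. It is made from compound 1 by one change: methyl in place of dimethylcarbamoyl on an aromatic carbon. The rest of the shared core is untouched.

Going by the values given here, no step for exactly this change exists among the measured compounds. Among the compounds with values here, the only hint is that compound 2, which carries a small group in the same place along with a different chain, gives 1400 nM. On this basis compound 3 is expected to show a modest move toward a lower number, a step of a 2.2-fold lower number from compound 1 to compound 3 (0.34 log units; beyond the scatter), possibly within the scatter. The expected value for compound 3 is 3000 nM, with a range from 700 nM to 12000 nM.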

Compound 3, inhibition constant: 1900 nM
Beside the measured number, compound 3's estimate is 1.6-fold (0.20 log units) above it, within the range that was stated.
By their numbers in this assay, from the lowest: compounds 2 and 3 (each within the scatter of the next); then compound 1.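

In this assay, for the compounds shown here, replacing dimethylcarbamoyl with methyl on this aromatic carbon gives the first single-change comparison at this position: a 3.4-fold lower number from compound 1 to compound 3 (0.53 log units; beyond the scatter). The position therefore responds to the group it carries, and the dimethylcarbamoyl group, with its five heavy atoms, its carbonyl and its hydrogen-bond acceptor, is not needed for the binding seen with compound 3, which keeps only one carbon there. Nothing measured here explains what lies behind this step.

Going by these compounds alone, compound 2 differs from both compound 1 and compound 3 in more than one place, so no step to it can be read, and the effect of its trifluoromethyl group cannot be separated from that of its different chain. From the compounds shown here alone, it also remains open whether the size of the group or its carbonyl matters more, a question that an acetyl group, which keeps the carbonyl, and an isopropyl group, which has none, could help to answer on the same core and chain.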